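Swapping a Methoxyphenyl for a Difluorophenyl Amide

The source may report more compounds than this note shows. Statements on the series, on what has been measured and on what is new or still open speak of the compounds shown alone.

Three compounds share one core and differ only in the aryl group on the amide nitrogen. Compound 1 `COc1ccc2nc(C)cc(OCC(=O)Nc3ccccc3)c2c1` carries a plain phenyl; in a toxicity assay on HepG2 cells (Homo sapiens) for inhibition, read by CellTiter-Glo, with a stated time of 48 h (a lower number here means a stronger inhibitor, a higher number a weaker inhibitor), compound 1 gives 39800 nM. Compound 2 `COc1ccc2nc(C)cc(OCC(=O)Nc3cc(C)ccc3C)c2c1` carries a 2,5-dimethylphenyl. In this assay compound 2 reaches only the limit of the measurement, > 100000 nM. Compound 3 `COc1ccc(NC(=O)COc2cc(C)nc3ccc(OC)cc23)cc1` carries a 4-methoxyphenyl. In this assay compound 3 likewise sits at the limit, > 100000 nM, so for compound 3 no exact number is known, only a limit. The steps of an at least 2.5-fold higher number from compound 1 to compound 2 (0.40 log units; beyond the scatter) and an at least 2.5-fold higher number from compound 1 to compound 3 (0.40 log units; beyond the scatter) both show that adding groups to the phenyl weakened inhibition at least modestly, while a step that the two limits leave unreadable from compound 2 to compound 3 cannot be sized, as the limit of > 100000 nM in this assay, at which 2 of the 3 values shown sit, shows. Compound 4 `COc1ccc2nc(C)cc(OCC(=O)Nc3cc(F)cc(F)c3)c2c1` makes the change (3,5-difluorophenyl in place of 4-methoxyphenyl on an amide-type nitrogen). On that evidence, compound 4 is expected to stay close to the limit as well. The step of an at least 1.1-fold lower number from compound 3 to compound 4 (0.04 log units; that floor lies within the scatter) is therefore expected to be small or not readable. The estimate for compound 4 in this assay is 90000 nM, between 30000 nM and 300000 nM.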

Compound 4, half-maximal inhibitory concentration: > 100000 nM
Compound 4: only a limit was reported (the forecaster's own chance of this, stated with the estimate: 60%); middle value at least 1.1-fold (0.04 log units) from the limit.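

In this assay, the step of an at least 2.5-fold higher number from compound 1 to compound 4 (0.40 log units; beyond the scatter) shows that a ring carrying fluorine also gives a weaker inhibitor than the plain phenyl. Among the compounds shown, all three substituted rings on the amide-type nitrogen therefore give weaker inhibitors than phenyl, and none goes against this. The steps linking compound 2, compound 3 and compound 4 to one another cannot be read, because their values are limits and not numbers: the limit of > 100000 nM in this assay, at which 3 of the 4 values shown sit.

On these data alone, it remains open how far beyond the limit compound 2, compound 3 and compound 4 lie, and so whether swapping 4-methoxyphenyl for 3,5-difluorophenyl changes anything at all. Also open, as far as these compounds go, is whether a phenyl carrying an amine or a carboxylic acid would give a stronger inhibitor than compound 1.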